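The source may hold more compounds than are shown below. What is called first, only, known or untested is meant among the compounds shown, and "the series" means these compounds.

Working notes on the series.

Three members share one core and differ only in the aryl amide. Compound 1 `Cc1ccc(C(=O)Nc2cccc(-c3oc4cc(-c5ccc(F)cc5)ccc4c(=O)c3O)c2)cc1` carries a 4-methylphenyl on the carbonyl carbon and in a functional assay on HepG2 cells (Homo sapiens) for antiproliferative activity, read by CCK-8 assay, with a stated time of 72 h (a lower number here means a stronger inhibitor, a higher number a weaker inhibitor), compound 1 gives 2320 nM. Compound 2 `O=C(Nc1cccc(-c2oc3cc(-c4ccc(F)cc4)ccc3c(=O)c2O)c1)c1ccc(Cl)cc1` gives 11000 nM, and compound 3 `O=C(Nc1cccc(-c2oc3cc(-c4ccc(F)cc4)ccc3c(=O)c2O)c1)c1ccc(F)cc1F` gives 26400 nM. Compound 3 therefore holds the highest number of the three, with a 2.4-fold higher number from compound 2 to compound 3 (0.38 log units; beyond the scatter) and an 11-fold higher number from compound 1 to compound 3 (1.06 log units; beyond the scatter); the chloro-for-methyl exchange alone reads a 4.7-fold higher number from compound 1 to compound 2 (0.68 log units; beyond the scatter).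

Compound 4 `O=C(Nc1cccc(-c2oc3cc(-c4ccc(F)cc4)ccc3c(=O)c2O)c1)c1ccc(C(F)(F)F)cc1` is not yet measured. The change from compound 3 is 4-(trifluoromethyl)phenyl in place of 2,4-difluorophenyl on a carbonyl carbon. Among the measured compounds shown here, no measured step covers this exact exchange; the steps that bear on it are those among the three aryl amides, all of which moved the number by modest to large amounts, and the two four-substituted phenyls both sit below compound 3. On that basis a modest fall in this assay is expected, a 2.6-fold lower number from compound 3 to compound 4 (0.42 log units; beyond the scatter), placing compound 4 near compound 2 rather than compound 1. The estimate for compound 4 is 10000 nM, with a range of 3000 nM to 35000 nM.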

Compound 4, half-maximal inhibitory concentration: 42700 nM
The estimate for compound 4 lay 4.3-fold (0.63 log units) below the measured number; measured number above the stated range.
By their numbers in this assay, from the lowest: compound 1; then compound 2; then compounds 3 and 4 (each within the scatter of the next).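

In this assay the 4-(trifluoromethyl)phenyl amide does not separate from the 2,4-difluorophenyl amide, with a 1.6-fold higher number from compound 3 to compound 4 (0.21 log units; within the scatter) so compound 4 goes against the earlier reading that compound 3 stood alone at the top of the series. On the same aromatic carbon, trifluoromethyl stands apart from chloro, with a 3.9-fold higher number from compound 2 to compound 4 (0.59 log units; beyond the scatter) and further still from methyl, with an 18-fold higher number from compound 1 to compound 4 (1.26 log units; beyond the scatter) so compounds 1, 2 and 4 rise in the order methyl, chloro, trifluoromethyl. No measurement shown here accounts for that order.

On these data alone, whether a methoxy group, an amine or a carboxylic acid on that aromatic carbon would fall in with methyl or with trifluoromethyl remains open. Also open, as far as these compounds go, is whether the order holds with a group other than the 4-fluorophenyl on the shared core.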